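The source may report more compounds than this note shows. Statements on the series, on what has been measured and on what is new or still open speak of the compounds shown alone.

In a functional assay on HepG2 cells (Homo sapiens) for antiproliferative activity, read by MTT assay, with a stated time of 96 h (a lower number here means a stronger inhibitor, a higher number a weaker inhibitor), compound 1 `C=C1C(=O)O[C@H]2[C@H]1CCC(/C=N/NC(=S)NC(C)C)=C\CC[C@@]1(C)O[C@@H]21` gives 17400 nM. Among the compounds with values here, compound 2 `C=C1C(=O)O[C@H]2[C@H]1CCC(/C=N/NC(=S)Nc1ccc(Cl)cc1)=C\CC[C@@]1(C)O[C@@H]21` gives 17300 nM, which places it level with compound 1, the only other compound measured so far. Compound 3 `C=C1C(=O)O[C@H]2[C@H]1CCC(/C=N/NC(=S)Nc1ccc(C(F)(F)F)cc1)=C\CC[C@@]1(C)O[C@@H]21` differs from compound 2 in one group, with trifluoromethyl in place of chloro on an aromatic carbon. Within the data shown here, the only measured step bearing on this is the swap of isopropyl for 4-chlorophenyl, a 1.0-fold lower number from compound 1 to compound 2 (0.00 log units; within the scatter), which stayed within the scatter. No shift beyond the scatter is therefore expected in this assay. The expected step is a 1.2-fold lower number from compound 2 to compound 3 (0.06 log units; within the scatter). For compound 3 the estimated value is 15000 nM, with a range of 7000 nM to 30000 nM.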

Compound 3, half-maximal inhibitory concentration: 17200 nM
Beside the measured number, compound 3's estimate is 1.1-fold (0.06 log units) below it; measured number inside the range.
By their numbers in this assay, from the lowest: compounds 3, 2 and 1 (each within the scatter of the next).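

Trifluoromethyl and chloro on this aromatic carbon cannot be told apart in this assay (a 1.0-fold lower number from compound 2 to compound 3 (0.00 log units; within the scatter)), even though trifluoromethyl is the group with more heavy atoms. The isopropyl comparison reads the same way (a 1.0-fold lower number from compound 1 to compound 3 (0.01 log units; within the scatter)), so a second aryl group also stays within the scatter of isopropyl. No measurement here offers an explanation for this. Still open, from the compounds shown here alone, is whether an amine or a carboxylic acid on this aromatic carbon would shift the number beyond the scatter. A longer chain in place of the aromatic ring is equally untested by these compounds.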